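Carboxyphenyl variant of the diaryl pyrazolopyridine ketone series

The compounds below may be only part of what the source reports. "The series", "measured", "known", "first", "only" and "open" are said of these compounds alone.

Among the compounds with values here, compound 1 `CCCS(=O)(=O)Nc1ccc(F)c(C(=O)c2n[nH]c3ncc(-c4cccc(N)c4)cc23)c1F` stands second highest of the three numbers measured so far in an assay for binding affinity to dual specificity mitogen-activated protein kinase kinase 4 (Homo sapiens), read by KINOMEscan, tested at 100 nM (a lower number here means a stronger effect, a higher number a weaker effect of the compound at the concentration tested), at 1.6%. Compound 2 `CCCS(=O)(=O)Nc1ccc(F)c(C(=O)c2n[nH]c3ncc(-c4ccc(N)cc4)cc23)c1F` gives 0.1% in this assay, and the step of a number 1.5 percentage points lower from compound 1 to compound 2 (within the scatter) is within the scatter. Compound 3 `CCCS(=O)(=O)Nc1ccc(F)c(C(=O)c2n[nH]c3ncc(-c4ccc(C(F)(F)F)cc4)cc23)c1F` gives 29%, and the step of a number 27.4 percentage points higher from compound 1 to compound 3 (beyond the scatter) is beyond the scatter, as is a number 28.9 percentage points higher from compound 2 to compound 3 (beyond the scatter).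

The change to compound 4 `CCCS(=O)(=O)Nc1ccc(F)c(C(=O)c2n[nH]c3ncc(-c4ccc(C(=O)O)cc4)cc23)c1F` is 4-carboxyphenyl in place of 3-aminophenyl on an aromatic carbon. Within the data shown here, two measured steps bear on it: the exchange of the aminophenyl pattern in a number 1.5 percentage points lower from compound 1 to compound 2 (within the scatter) changed nothing beyond the scatter, while the exchange of amino for trifluoromethyl in a number 28.9 percentage points higher from compound 2 to compound 3 (beyond the scatter) raised the number modestly. Among the measured compounds shown here, the entering 4-carboxyphenyl keeps one hydrogen-bond donor and one hydrogen-bond acceptor, as the leaving group had, but no carboxy-bearing analogue has been measured, so an intermediate outcome is expected. Compound 4 is estimated at 8% in this assay, range 0.5% to 35%, which means an expected step of a number 6.4 percentage points higher from compound 1 to compound 4 (within the scatter), probably within or only just beyond the scatter.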

Compound 4, a percentage reported as activity, at one concentration (the size of the read-out at that concentration, not a potency): 0.1%
Compound 4: the middle estimate sits 7.9 percentage points above what was measured; measured number below the stated range.
By their numbers in this assay, from the lowest: compounds 2, 4 and 1 (each within the scatter of the next); then compound 3.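

In this assay the 4-carboxyphenyl group of compound 4 falls with the two aminophenyl groups (a number 1.5 percentage points lower from compound 1 to compound 4 (within the scatter)) and carboxy in place of amino in the same 4-substituted phenyl leaves the number unmoved (no change at the digits printed from compound 2 to compound 4 (within the scatter)). Carboxy in place of trifluoromethyl gives the only large change in this set (a number 28.9 percentage points lower from compound 3 to compound 4 (beyond the scatter)), so compound 3 stands apart from the other three, and the higher number seen there does not follow from losing the amino group as such. No measured evidence in hand accounts for this difference.

On these data alone, whether an amide, a methyl ester or a nitrile in place of the carboxy group stays with compound 4 or moves toward compound 3 remains open. The read-out is taken at one concentration, so it gives no potency and leaves compounds 1, 2 and 4 unresolved from one another.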